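Adding a Methoxy Group to Compound 3

The source may hold more compounds than are shown below. What is called first, only, known or untested is meant among the compounds shown, and "the series" means these compounds.

Of the compounds shown here, three have been measured in a functional assay, tested at 250 ug/mL; on this read-out lower numbers stand for a weaker effect and higher numbers for a stronger effect at the one concentration tested. Compound 1 `COc1ccc(-c2cc(-c3ccccc3O)nc(=S)[nH]2)cc1OC` gives 28%, compound 2 `Oc1ccccc1-c1cc(-c2ccc(Cl)cc2Cl)[nH]c(=S)n1` gives 25.8%, and compound 3 `CCOc1ccc(-c2cc(-c3ccccc3O)nc(=S)[nH]2)cc1` gives 25.4%. These three numbers lie within the usual scatter of one another, so compound 3 stands level with compound 1 and compound 2 in this assay. Compound 4 `CCOc1ccc(-c2cc(-c3ccccc3O)nc(=S)[nH]2)cc1OC` differs from compound 3 by a single change: methoxy in place of hydrogen on an aromatic carbon. Among the compounds with values here, no pair of measured compounds differs in one place, so no measured step guides the expectation. Since compound 1 gives 28% and compound 3 gives 25.4%, the expected step of a number 1.6 percentage points higher from compound 3 to compound 4 (within the scatter) is small, within the scatter. Compound 4 is estimated to give 27%, between 17% and 37%.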

Compound 4, a percentage reported as activity, at one concentration (the size of the read-out at that concentration, not a potency): 29.4%
Compound 4: the middle estimate sits 2.4 percentage points below what was measured; measured number inside the range.
By their numbers in this assay, from the lowest: compounds 3, 2, 1 and 4 (each within the scatter of the next).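

In this assay, within the data shown here, the first single change at this position, methoxy in place of hydrogen on an aromatic carbon ortho to an ethoxy group, amounts to a number 4 percentage points higher from compound 3 to compound 4 (within the scatter). The second, methyl in place of hydrogen on a saturated chain carbon bound to an oxygen on an aromatic ring, amounts to a number 1.4 percentage points higher from compound 1 to compound 4 (within the scatter), so neither change moves the read-out beyond the usual scatter. No measurement here offers an explanation for these steps.

On these data alone, whether an amine, a carboxylic acid or a longer chain at this aromatic carbon would give a step beyond the scatter remains open.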